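The source may hold more compounds than are shown below. What is called first, only, known or untested is meant among the compounds shown, and "the series" means these compounds.

Measured so far:
- compound 1 `Fc1ccc(-c2nn3c(NC4CCCC4)cccc3c2-c2ccsc2)cc1` — "not determined" (no result reported)
- compound 2 `Nc1nccc(-c2c(-c3ccc(F)cc3)nn3c(NC4CCCC4)cccc23)n1` — 46000 nM
- compound 3 `NNc1cc(-c2c(-c3ccc(F)cc3)nn3c(NC4CCCC4)cccc23)ccn1` — 40000 nM

In an ADME assay on Vero cells (Chlorocebus sabaeus) for cytotoxicity (on this read-out lower numbers stand for higher toxicity in this test and higher numbers for lower toxicity in this test), compound 3 gives the lowest of the two numbers, yet the step of a 1.2-fold lower number from compound 2 to compound 3 (0.06 log units; within the scatter) shows that it and compound 2 are within the scatter of each other, so no order can be read between them. Compound 1 has no result in this assay.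

Compound 4 `Fc1ccc(-c2nn3c(NC4CCCC4)cccc3c2-c2c[nH]c(NC3CCCC3)n2)cc1` follows from compound 3 by 2-(cyclopentylamino)-1H-imidazol-4-yl in place of 2-(aminoamino)pyridin-4-yl on an aromatic carbon. Within the data shown here, no measured step covers this change; the only step available, from compound 2 to compound 3, exchanges the same position and stays within the scatter. The expectation is therefore a step of a 1.3-fold lower number from compound 3 to compound 4 (0.12 log units; within the scatter), with no direction clearly beyond the scatter. Compound 4 is estimated at 30000 nM, with a range from 12000 nM to 70000 nM.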

Compound 4, half-maximal cytotoxic concentration: 40000 nM
The estimate for compound 4 lay 1.3-fold (0.12 log units) below the measured number; low and high end bracket the measured number.
By their numbers in this assay, from the lowest: compounds 3, 4 and 2 (each within the scatter of the next).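

In this assay the exchange at this aromatic carbon now brings in a five-membered aromatic ring with a carbon-only ring attached, and the number stays put (no change at the digits printed from compound 3 to compound 4 (within the scatter)) and also sits close to that of the aminopyrimidine compound (a 1.2-fold lower number from compound 2 to compound 4 (0.06 log units; within the scatter)). All three groups tried here therefore read alike, and no order can be drawn among them. Nothing measured here speaks to why they read alike.

From the compounds shown here alone, it remains open whether a carboxylic acid on this ring, or a longer chain in place of the cyclopentyl group, would move the number beyond the scatter.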